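Notes on the anilino series: cyclopropyl to isopropyl

The source may hold more compounds than are shown below. What is called first, only, known or untested is meant among the compounds shown, and "the series" means these compounds.

Compound 1 `Cc1cc(=O)oc2cc(OCc3nc(N)nc(Nc4ccc(F)cc4)n3)ccc12`, compound 2 `Cc1cc(=O)oc2cc(OCc3nc(N)nc(Nc4cccc(Cl)c4)n3)ccc12` and compound 3 `Cc1cc(=O)oc2cc(OCc3nc(N)nc(Nc4ccc(C5CC5)cc4)n3)ccc12` share one core and differ only in the aryl on the amine. In an assay on COS-7 cells for agonist activity at Free fatty acid receptor 1 (Homo sapiens), read by scintillation counting and inositol phosphate accumulation, with a stated time of 90 min (on this read-out lower numbers stand for an effect already at smaller amounts and higher numbers for an effect only at larger amounts of compound), compound 1 gives 18300 nM, compound 2 gives 1110 nM and compound 3 gives 700 nM. Both a 16-fold lower number from compound 1 to compound 2 (1.22 log units; beyond the scatter) and a 26-fold lower number from compound 1 to compound 3 (1.42 log units; beyond the scatter) are large, whereas a 1.6-fold lower number from compound 2 to compound 3 (0.20 log units; within the scatter) stays within the scatter, so compound 3 holds the lowest number of the three without standing apart from compound 2. Compound 4 `Cc1cc(=O)oc2cc(OCc3nc(N)nc(Nc4ccc(C(C)C)cc4)n3)ccc12` carries isopropyl in place of cyclopropyl on an aromatic carbon. Among the measured compounds shown here, no measured step exchanges one para group for another of equal size; a 26-fold lower number from compound 1 to compound 3 (1.42 log units; beyond the scatter) only shows that cyclopropyl at this place goes with a low number. The step of a 1.1-fold higher number from compound 3 to compound 4 (0.03 log units; within the scatter) is therefore expected to remain within the scatter. For compound 4 the estimate in this assay is 750 nM, with a range from 280 nM to 2000 nM.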

Compound 4, half-maximal effective concentration: 460 nM
Estimate against measurement, compound 4: 1.6-fold (0.21 log units) above; the range from low to high includes it.
By their numbers in this assay, from the lowest: compounds 4, 3 and 2 (each within the scatter of the next, the first and the last beyond it); then compound 1.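

Isopropyl in place of cyclopropyl on this aromatic carbon gives a 1.5-fold lower number from compound 3 to compound 4 (0.18 log units; within the scatter) in this assay, so within this pair the three-membered ring is not required for a low number. The step of a 2.4-fold lower number from compound 2 to compound 4 (0.38 log units; beyond the scatter) is modest and a 40-fold lower number from compound 1 to compound 4 (1.60 log units; beyond the scatter) is large, so the open-chain group also stands clear of the 3-chlorophenyl and 4-fluorophenyl compounds. Nothing available explains these steps.

Going by these compounds, whether tert-butyl, a longer alkyl chain or a carboxylic acid on this aromatic carbon keeps the number this low remains open.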